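Ethyl in Place of Hydrogen on an Oxygen: Compound 3

This account rests on a few compounds, and the source may have more. Where it says the series, first, only, none or still open, it means among the compounds named here.

Measured so far in an assay on isolated protein for inhibition of kallikrein-7 (Homo sapiens), read by fluorescence, with stated times of 10 min and 30 min; a lower number here means a stronger inhibitor, a higher number a weaker inhibitor:
compound 1, `COc1ccc(Cl)cc1C[C@@H]1CN/C(=N\O)CN(CC(=O)Nc2cccc(C(=O)O)c2)C1=O` — > 30000 nM
compound 2, `COc1ccc(Cl)cc1C[C@@H]1CNC(=O)CN(CC(=O)Nc2ccc(O)c(C(=O)O)c2)C1=O` — compound 2 gives > 30000 nM

Compound 1 receives in this assay only a limit, not a number: > 30000 nM. Compound 2 likewise receives a limit, > 30000 nM. Among the measured compounds shown here, compound 1 therefore stands at no point on a scale of numbers; both results so far rest at the limit of > 30000 nM in this assay, at which 2 of the 2 values shown sit, so there is nothing yet to order and no step between measured compounds to draw on.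

Compound 3, `CCO/N=C1/CN(CC(=O)Nc2cccc(C(=O)O)c2)C(=O)[C@H](Cc2cc(Cl)ccc2OC)CN1`, differs from compound 1 in a single place: ethyl in place of hydrogen on an oxygen. Because (the limit of > 30000 nM in this assay, at which 2 of the 2 values shown sit), no change beyond the usual scatter is expected from this addition, in either direction, and the new compound is expected to remain beyond reach of the assay. The step that the limit leaves unreadable from compound 1 to compound 3 is accordingly estimated as none beyond the scatter. Compound 3 is expected to give about 40000 nM, within a range from 10000 nM to 200000 nM, most probably reported once more as a limit rather than as a number.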

Compound 3, half-maximal inhibitory concentration: 13000 nM
Compound 3: the middle estimate sits 3.1-fold (0.49 log units) above what was measured, within the range that was stated.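

In this assay, compound 3 gives 13000 nM, the only value among the three compounds shown that is an actual number. Compound 1 gives > 30000 nM, which is a limit and not a number. The change of hydroxy to ethoxy, on an oxygen whose other neighbour is a double-bonded nitrogen, gives an at least 2.3-fold lower number from compound 1 to compound 3 (0.36 log units; beyond the scatter), so this oxygen is a place where a small change on the core of compound 1 brings a compound into the measurable range of this assay.

A longer chain such as propyl or butyl on this oxygen, or a chain ending in an amine or a carboxylic acid, would show whether the number keeps falling as the group grows or whether ethyl is already enough. The full size of the step also stays open, since only the compound 3 end of it is a number, and the rest of the set offers no second number to compare with: the limit of > 30000 nM in this assay, at which 2 of the 3 values shown sit.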